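The source may report more compounds than this note shows. Statements on the series, on what has been measured and on what is new or still open speak of the compounds shown alone.

Three compounds share one core and differ only in the group carried on the amide nitrogen: compound 1 `CN(Cc1ccc(F)cc1)C(=O)c1ccc(-c2cc(C3=CC(=O)C=CC3=O)no2)s1`, compound 2 `CCCN(C)C(=O)c1ccc(-c2cc(C3=CC(=O)C=CC3=O)no2)s1` and compound 3 `O=C1C=CC(=O)C(c2cc(-c3ccc(C(=O)N4CCCC4)s3)on2)=C1`. In a functional assay on A549 cells (Homo sapiens) for cytotoxicity, read by XTT assay, with a stated time of 72 h (on this read-out lower numbers stand for stronger inhibition and higher numbers for weaker inhibition), compound 1 gives only a limit, > 30000 nM. In this assay compound 2 likewise gives only a limit, > 30000 nM. In this assay compound 3 also gives only a limit, > 30000 nM. Compound 2 therefore stands where all three stand, at the limit of > 30000 nM in this assay, at which 3 of the 3 values shown sit, and none of the steps between them can be sized: a step that the two limits leave unreadable from compound 1 to compound 2, a step that the two limits leave unreadable from compound 1 to compound 3 and a step that the two limits leave unreadable from compound 2 to compound 3. Compound 4 `COc1ccc(CN(C)C(=O)c2ccc(-c3cc(C4=CC(=O)C=CC4=O)no3)s2)cc1` differs from compound 2 in one place: 4-methoxyphenyl in place of ethyl on a saturated chain carbon bound to an amide-type nitrogen. A related group on that same carbon is already present in compound 1, and no sizeable step is expected because compound 1 gives only a limit, > 30000 nM. Compound 4 is expected to give 30000 nM, within 10000 nM to 100000 nM, most probably again only as a limit. The step from compound 2 to compound 4 is accordingly expected to be a number no higher from compound 2 to compound 4 (the limit leaves the size open).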

Compound 4, half-maximal inhibitory concentration: > 30000 nM
Compound 4: only a limit was reported (the forecaster's own chance of this, stated with the estimate: 85%); the middle value sits exactly at the limit.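

No new step can be read from compound 4 to compound 1 or compound 2, since each of these compounds gives only a limit in this assay and the sizes stay unreadable. All of the values shown sit together: the limit of > 30000 nM in this assay, at which 4 of the 4 values shown sit. The compounds shown leave open whether any group on the amide nitrogen of the shared core would give a measurable value, and how large these steps really are.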